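The source may report more compounds than this note shows. Statements on the series, on what has been measured and on what is new or still open speak of the compounds shown alone.

Compound 3 `O=C(Nc1ccc(C(F)(F)F)cc1)Nc1cc2ncncc2cc1OCc1cccc(Cl)c1` gives 5100 nM in a functional assay on GBM3 cells (Homo sapiens) for antiproliferative activity, read by WST assay, with a stated time of 72 h (on this read-out lower numbers stand for stronger inhibition and higher numbers for weaker inhibition), the lowest of the three numbers, though all its steps to the others fall within the scatter. Compound 2 `O=C(Nc1ccccc1F)Nc1cc2ncncc2cc1OCc1cccc(Cl)c1` gives 7500 nM and compound 1 `O=C(Nc1cccc(F)c1)Nc1cc2ncncc2cc1OCc1cccc(Cl)c1` gives 8300 nM. The steps of a 1.1-fold lower number from compound 1 to compound 2 (0.04 log units; within the scatter), a 1.6-fold lower number from compound 1 to compound 3 (0.21 log units; within the scatter) and a 1.5-fold lower number from compound 2 to compound 3 (0.17 log units; within the scatter) each vary only the aryl group on the urea nitrogen and leave the benzyloxy side of the shared core untouched. Compound 4 `O=C(Nc1ccc(C(F)(F)F)cc1)Nc1cc2ncncc2cc1OCc1ccccc1` differs from compound 3 on that other side: hydrogen in place of chloro on an aromatic carbon. For the measured compounds named here, no measured step bears on this change directly. With three aryl variations elsewhere giving nothing beyond the scatter, only a small shift is expected, a 1.4-fold higher number from compound 3 to compound 4 (0.14 log units; within the scatter), with no direction favoured. Compound 4 is therefore estimated at 7000 nM, range 3000 nM to 16000 nM.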

Compound 4, half-maximal inhibitory concentration: 3700 nM
Compound 4: middle estimate off by 1.9-fold (0.28 log units), on the high side; low and high end bracket the measured number.
By their numbers in this assay, from the lowest: compounds 4, 3, 2 and 1 (each within the scatter of the next, the first and the last beyond it).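

Replacing chloro with hydrogen on the benzyloxy side of the shared core in this assay gives a 1.4-fold lower number from compound 3 to compound 4 (0.14 log units; within the scatter). This first reading at this position leaves 3-chlorobenzyl and benzyl indistinguishable with the 4-(trifluoromethyl)phenyl group held on the urea nitrogen. Nothing available accounts for the result.

On these data alone, whether an amine, a carboxylic acid or a methoxy group at this aromatic carbon would move the number beyond the scatter remains open. As far as these compounds go, it is also open whether the same exchange behaves alike with the 2-fluorophenyl or 3-fluorophenyl group on the urea.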